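A few compounds are considered here, and "the series" means these few. Any claim that something is new, unique, unknown or untested is made for them only; others in the source may bear on it.

Measured so far:
- compound 1 `c1ccc(CNCc2cn(Cc3ccccc3)c3ccccc23)cc1` — 362000 nM
- compound 2 `C#CCN(C)Cc1cn(Cc2ccccc2)c2ccccc12` — 476000 nM
- compound 3 `CCNCc1cn(Cc2ccccc2)c2ccccc12` — 429000 nM

All three numbers come from an assay on isolated protein for inhibition of Amine oxidase [flavin-containing] B (Rattus norvegicus) (on this read-out lower numbers stand for stronger inhibition and higher numbers for weaker inhibition), and they sit close together. Compound 3 holds the second highest number of the set, but the step of a 1.1-fold lower number from compound 2 to compound 3 (0.05 log units; within the scatter) lies within the scatter, as does the step of a 1.2-fold higher number from compound 1 to compound 3 (0.07 log units; within the scatter), so none of the three can be told apart on this read-out; they share one core and differ only in the group carried on the amine.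

Compound 4 `CC(C)NCc1cn(Cc2ccccc2)c2ccccc12` is the next member. It differs from compound 3 by methyl in place of hydrogen on a saturated chain carbon bound to an amine nitrogen and a saturated chain carbon, which turns ethylamino into isopropylamino. Two earlier steps touch the same region of the molecule: the step of a 1.2-fold higher number from compound 1 to compound 3 (0.07 log units; within the scatter), where phenyl gave way to methyl on the carbon bound to the amine nitrogen, and the step of a 1.1-fold lower number from compound 2 to compound 3 (0.05 log units; within the scatter), where the whole amine substituent was exchanged. Both stayed within the scatter, even though they were larger changes than adding a single methyl. For compound 4 the expected step is therefore none beyond the scatter, written as a 1.0-fold higher number from compound 3 to compound 4 (0.02 log units; within the scatter). Compound 4 is estimated to give 450000 nM in this assay, with a likely range from 200000 nM to 1000000 nM.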

Compound 4, inhibition constant: 438000 nM
The estimate for compound 4 lay 1.0-fold (0.01 log units) above the measured number; the measured number falls inside the stated range.
By their numbers in this assay, from the lowest: compounds 1, 3, 4 and 2 (each within the scatter of the next).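

In this assay, one added methyl on the saturated chain carbon bound to the amine nitrogen and a saturated chain carbon, which turns ethylamino into isopropylamino, gives a 1.0-fold higher number from compound 3 to compound 4 (0.01 log units; within the scatter), so this small change to the amine group leaves no readable mark. The comparison with the two other amine groups ends the same way: a 1.1-fold lower number from compound 2 to compound 4 (0.04 log units; within the scatter) and a 1.2-fold higher number from compound 1 to compound 4 (0.08 log units; within the scatter), so isopropylamino cannot be told apart from either methyl(propargyl)amino or benzylamino on this read-out, and all four amine groups shown now read alike. No separate measurement is available to account for this result.

As far as these compounds go, what remains open is whether any group at this position can move the number beyond the scatter, for example a plain unsubstituted amine, tert-butylamino, or a carboxylic acid in place of the amine. The compounds shown also leave open what happens when the benzyl group on the shared core is replaced, for example by a methyl group, since all four compounds carry that benzyl group unchanged.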